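The compounds below may be only part of what the source reports. "The series", "measured", "known", "first", "only" and "open" are said of these compounds alone.

Within the data shown here, compound 1 `CCCCS(=O)(=O)Nc1cc(-c2ccc3ncnc(NCCN(C)C)c3c2)cnc1OC` gives 280 nM in a functional assay on MDA-MB-231 cells (Homo sapiens) for antiproliferative activity, read by sulforhodamine B assay, with a stated time of 72 h (on this read-out lower numbers stand for stronger inhibition and higher numbers for weaker inhibition), the lowest of the numbers so far, while compound 2 `COc1ncc(-c2ccc3ncnc(NCCN(C)C)c3c2)cc1NS(=O)(=O)c1ccc(F)cc1` gives 1220 nM. Compound 3 `CCCCS(=O)(=O)Nc1cc(-c2ccc3ncnc(NCc4ccncc4)c3c2)cnc1OC` keeps the butyl on the sulfonyl sulfur of compound 1 and alters the chain on the other side: pyridin-4-yl in place of (dimethylamino)methyl on a saturated chain carbon bound to a nitrogen on an aromatic ring. Among the measured compounds shown here, the only measured step, a 4.4-fold higher number from compound 1 to compound 2 (0.64 log units; beyond the scatter), concerns the sulfonyl sulfur, so it bears only indirectly, and no step at this chain has been measured. In this assay a step no larger than that one, leaning towards a higher number, is expected: a 1.6-fold higher number from compound 1 to compound 3 (0.21 log units; within the scatter). For compound 3 the estimated value is 450 nM, within a range of 130 nM to 1500 nM.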

Compound 3, half-maximal inhibitory concentration: 4320 nM
For compound 3 the middle estimate is 9.6-fold (0.98 log units) below the measured one, and the stated range ends below it.
By their numbers in this assay, from the lowest: compound 1; then compound 2; then compound 3.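

Placing pyridin-4-yl in place of (dimethylamino)methyl on a saturated chain carbon bound to a nitrogen on an aromatic ring gives a 15-fold higher number from compound 1 to compound 3 (1.19 log units; beyond the scatter) in this assay, so this chain, untouched by the earlier step, also affects the read-out while the butyl on the sulfonyl sulfur stays. Both groups count one hydrogen-bond acceptor and no net charge, so those counts do not separate them. Nothing measured here explains the step. Still open, on these data alone, is whether a morpholine or piperazine, or a longer chain ending in dimethylamino, would retain the value of compound 1 280 nM.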